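The source may report more compounds than this note shows. Statements on the series, on what has been measured and on what is new or still open speak of the compounds shown alone.

Three compounds share one core and differ only in two aryl groups. Compound 1 `CN(C(=O)NC(=O)c1ccc(F)c(F)c1)c1nc(C(F)(F)F)c(C(=O)N/N=C/c2ccc(C(F)(F)F)cc2)s1` gives 5.93 ug/mL in a functional assay on MCF7 cells (Homo sapiens) for inhibition, read by MTT assay, with a stated time of 72 h; a lower number here means a stronger inhibitor, a higher number a weaker inhibitor. Compound 2 `CN(C(=O)NC(=O)c1ccc(Cl)cc1Cl)c1nc(C(F)(F)F)c(C(=O)N/N=C/c2cccc(C(F)(F)F)c2)s1` gives 10.7 ug/mL in this assay. Compound 3 `CN(C(=O)NC(=O)c1ccc(Cl)cc1Cl)c1nc(C(F)(F)F)c(C(=O)N/N=C/c2ccc(C(F)(F)F)cc2)s1` gives 8.42 ug/mL in this assay, the second highest of the three numbers; its nearest neighbour is compound 2 and its furthest compound 1, and both gaps lie within the scatter. The step of a 1.4-fold higher number from compound 1 to compound 3 (0.15 log units; within the scatter) exchanges the aryl group on the carbonyl carbon, and the step of a 1.3-fold lower number from compound 2 to compound 3 (0.10 log units; within the scatter) exchanges the aryl group on the carbon with a double bond to nitrogen; neither moved the number beyond the scatter. Compound 4 `CN(C(=O)NC(=O)c1cccc(C(F)(F)F)c1)c1nc(C(F)(F)F)c(C(=O)N/N=C/c2ccc(C(F)(F)F)cc2)s1` has not yet been measured. It differs from compound 3 in one place: 3-(trifluoromethyl)phenyl in place of 2,4-dichlorophenyl on a carbonyl carbon. The step from compound 1 to compound 3 bears on this change: it altered the group at the same carbonyl carbon and stayed within the scatter. Compound 4 is therefore expected to show a step of a 1.1-fold lower number from compound 3 to compound 4 (0.02 log units; within the scatter), which is no change beyond the scatter. The estimate for compound 4 is 8 ug/mL, with a range from 4 ug/mL to 16 ug/mL.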

Compound 4, half-maximal inhibitory concentration: 6.5 ug/mL
Compound 4: the middle estimate sits 1.2-fold (0.09 log units) above what was measured; the measured number falls inside the stated range.
By their numbers in this assay, from the lowest: compounds 1, 4, 3 and 2 (each within the scatter of the next).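

In this assay, placing 3-(trifluoromethyl)phenyl on the carbonyl carbon gives a 1.3-fold lower number from compound 3 to compound 4 (0.11 log units; within the scatter) and a 1.1-fold higher number from compound 1 to compound 4 (0.04 log units; within the scatter) and so adds a third aryl group to this position without a change beyond the scatter. With 4-(trifluoromethyl)phenyl held fixed on the other side of the molecule, the position now accepts a ring bearing trifluoromethyl as well as rings bearing two chlorine or two fluorine atoms, and the number stays within the scatter for all three. No supporting measurement is available to explain this result.

Every group shown at this carbonyl carbon is a substituted phenyl ring, so it remains open whether an amine or a carboxylic acid on that ring, or a longer alkyl chain in its place, would shift the number beyond the scatter. From the compounds shown here alone, whether 3-(trifluoromethyl)phenyl behaves the same way alongside 3-(trifluoromethyl)phenyl on the carbon with a double bond to nitrogen also stays open.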